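The compounds below may be only part of what the source reports. "The series", "measured", "known", "first", "only" and "open" are said of these compounds alone.

Going by the values given here, compound 1 `CC1(C)S[C@@H]2/C(=C\C(=O)c3ccc4ccccc4c3)C(=O)N2[C@H]1C(=O)OC(c1ccccc1)c1ccccc1` is the only compound here with a number: in a functional assay on A-375 cells (Homo sapiens) for cytotoxicity, read by MTT assay, with a stated time of 48 h (on this read-out lower numbers stand for stronger inhibition and higher numbers for weaker inhibition), compound 1 gives 36500 nM. Compound 2 `CC(=O)/C=C1\C[C@H]2SC(C)(C)[C@H](C(=O)OC(c3ccccc3)c3ccccc3)N2C1=O` reaches only the limit of this assay, at > 100000 nM. Compound 3 `COC(=O)/C=C1\C[C@H]2SC(C)(C)[C@H](C(=O)OC(c3ccccc3)c3ccccc3)N2C1=O` likewise stops at the limit, with > 100000 nM. The step that the two limits leave unreadable from compound 2 to compound 3 puts methoxy in place of methyl on a carbonyl carbon, and its size is unreadable because of the limit of > 100000 nM in this assay, at which 2 of the 3 values shown sit. Compound 4 `CC1(C)S[C@@H]2/C(=C\C(=O)OCc3ccccc3)C(=O)N2[C@H]1C(=O)OC(c1ccccc1)c1ccccc1` arises from compound 1 by a change of the same kind, (benzyloxy in place of naphthalen-2-yl on a carbonyl carbon). Among the compounds with values here, no measured step bears readably on it, so the expectation rests on the weak standing of compound 1 alone: the estimated step of a 2.2-fold higher number from compound 1 to compound 4 (0.34 log units; beyond the scatter) is expected to run toward weaker inhibition, with a fair chance of ending at the limit. Compound 4 is therefore expected to give 80000 nM, within 30000 nM to 200000 nM.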

Compound 4, half-maximal inhibitory concentration: 7100 nM
Compound 4: the middle estimate sits 11-fold (1.05 log units) above what was measured, and the stated range ends above it.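

Going by these compounds alone, the group on this carbonyl carbon clearly affects the read-out: benzyloxy in place of naphthalen-2-yl brings a 5.1-fold lower number from compound 1 to compound 4 (0.71 log units; beyond the scatter), the first readable step at this place, and it runs toward stronger inhibition. In this pair, the second aromatic ring of naphthalen-2-yl is not needed for activity. Nothing shown accounts for the gain. On these data alone, the change removes one aromatic ring and adds an oxygen together, so their shares remain open. Phenyl or benzylamino on the same carbonyl carbon could help separate them.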